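The compounds below may be only part of what the source reports. "The series", "measured", "known", "first", "only" and "open" are said of these compounds alone.

Compound 1 `NS(=O)(=O)OC[C@@H]1C[C@@H](n2nnc3c(NCc4cccs4)ncnc32)C[C@@H]1O` carries (thiophen-2-yl)methyl on a nitrogen on an aromatic ring; in an assay on a protein complex for inhibition of NEDD8 activating enzyme (Homo sapiens), read by HTRF, with a stated time of 2 h, in the presence of a further agent that is not named here (a higher number here means a weaker inhibitor, a lower number a stronger inhibitor), compound 1 gives 15.9 nM. Compound 2 `NS(=O)(=O)OC[C@@H]1C[C@@H](n2nnc3c(NC4CCCC4)ncnc32)C[C@@H]1O` has cyclopentyl on that nitrogen instead. In this assay compound 2 reaches only > 10000 nM, which is a limit of the assay and not a number. The step of an at least 620-fold higher number from compound 1 to compound 2 (2.79 log units; beyond the scatter) is accordingly known only as a bound because of the limit of > 10000 nM in this assay, at which 1 of the 2 values shown sits. Compound 2 thus stands at the weak end of the two values shown. Compound 3 `NS(=O)(=O)OC[C@@H]1C[C@@H](n2nnc3c(Nc4cnc5ccccn45)ncnc32)C[C@@H]1O` is not yet measured in this assay; it differs from compound 2 by a group of 9 heavy atoms (7 carbon, 2 nitrogen; one five-membered aromatic ring with 2 hetero atoms, one six-membered aromatic ring with 1 hetero atom) in place of a group of 5 heavy atoms (5 carbon; one five-membered non-aromatic ring of carbon only), on a nitrogen on an aromatic ring. Among the measured compounds shown here, the single measured step bears on it in reverse: moving from an aromatic-bearing group to cyclopentyl lost a large, bounded amount, so returning to an aromatic group on that nitrogen is expected to recover much of it, with an expected step of an at least 33-fold lower number from compound 2 to compound 3 (1.52 log units; beyond the scatter). The estimate for compound 3 is 300 nM, ranging from 20 nM to 5000 nM.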

Compound 3, half-maximal inhibitory concentration: > 10000 nM
Compound 3 was reported as a limit; the forecaster's own chance of this, stated with the estimate: 20%; middle value at least 33-fold (1.52 log units) away from the limit.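

In this assay compound 3 gives > 10000 nM, which is a limit of the assay. Putting this group of two aromatic rings on the nitrogen in place of (thiophen-2-yl)methyl gives an at least 620-fold higher number from compound 1 to compound 3 (2.79 log units; beyond the scatter), so an aromatic ring on this nitrogen does not by itself keep the activity, and of the three compounds only compound 1 gives a number. The step between compound 2 and compound 3 cannot be read, because both compounds sit at a limit: the limit of > 10000 nM in this assay, at which 2 of the 3 values shown sit.

The compounds shown leave open whether the activity of compound 1 follows the thiophene ring or the methyl link that joins it to the nitrogen; benzyl, or thiophen-2-yl set directly on the nitrogen, would separate the two. As far as these compounds go, the role of the ring sulfur also stays open, and furan-2-ylmethyl would test it.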